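A few compounds are considered here, and "the series" means these few. Any claim that something is new, unique, unknown or untested is made for them only; others in the source may bear on it.

Among the measured compounds shown here, in a functional assay on HepG2 cells (Homo sapiens) for inhibition, read by MTT assay, with a stated time of 48 h (a lower number here means a stronger inhibitor of growth, a higher number a weaker inhibitor of growth), three compounds sharing one core have numbers so far. Compound 1 `Cn1cc(C2CC(c3ccccc3)=NN2C(=O)c2cccnc2)c2cc(Br)ccc21`, with a phenyl group, gives 2520 nM, and compound 2 `Cn1cc(C2CC(c3ccc(Br)cc3)=NN2C(=O)c2cccnc2)c2cc(Br)ccc21`, with a 4-bromophenyl group, gives 6910 nM. Compound 3 `COc1ccc(C2=NN(C(=O)c3cccnc3)C(c3cn(C)c4ccc(Br)cc34)C2)cc1OC`, with a 3,4-dimethoxyphenyl group, gives 2450 nM, which matches compound 1 within the scatter. The comparison with the bromo compound shows a 2.8-fold lower number from compound 2 to compound 3 (0.45 log units; beyond the scatter).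

The next structure, compound 4 `COc1cc(C2=NN(C(=O)c3cccnc3)C(c3cn(C)c4ccc(Br)cc34)C2)cc(OC)c1OC`, changes 3,4-dimethoxyphenyl to 3,4,5-trimethoxyphenyl: methoxy in place of hydrogen on an aromatic carbon. In words, this is methoxy in place of hydrogen on an aromatic carbon.

For the measured compounds named here, the closest precedent is the change from phenyl to 3,4-dimethoxyphenyl, which gave a 1.0-fold lower number from compound 1 to compound 3 (0.01 log units; within the scatter). Bromo in place of hydrogen gave a 2.7-fold higher number from compound 1 to compound 2 (0.44 log units; beyond the scatter), so a change on this aromatic ring can still shift the number modestly. On that evidence, the expected step is a 1.1-fold lower number from compound 3 to compound 4 (0.03 log units; within the scatter), with no clear move in either direction. The estimate for compound 4 is 2300 nM, with an expected range from 1000 nM to 5500 nM.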

Compound 4, concentration for 50% growth inhibition: > 10000 nM
Compound 4 was reported as a limit; the forecaster's own chance of this, stated with the estimate: 2%; at least 4.3-fold (0.63 log units) between middle value and limit.
By their numbers in this assay, from the lowest: compounds 3 and 1 (each within the scatter of the next); then compound 2. At a limit, above all of these: compound 4.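

Compound 4 stands only as a limit in this assay, not as a measured number: the limit of > 10000 nM in this assay, at which 1 of the 4 values shown sits. Even so, this ring proved sensitive to a single added methoxy, with an at least 4.0-fold higher number from compound 3 to compound 4 (0.61 log units; beyond the scatter), whereas the larger change from phenyl to 3,4-dimethoxyphenyl had stayed within the scatter, with a 1.0-fold lower number from compound 1 to compound 3 (0.01 log units; within the scatter). The 3,4,5-trimethoxyphenyl group also gives an at least 3.9-fold higher number from compound 1 to compound 4 (0.59 log units; beyond the scatter), but the comparison with the 4-bromophenyl group gives only an at least 1.4-fold higher number from compound 2 to compound 4 (0.16 log units; that floor lies within the scatter), a floor that does not by itself separate those two compounds.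

On these data alone, how far the true value of compound 4 lies past its limit stays open. So does whether a hydroxy group, an amine or an ethoxy group in the same place would give a similar result to the added methoxy.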